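The source may report more compounds than this note shows. Statements on the series, on what has been measured and on what is new or still open speak of the compounds shown alone.

Measured in an ADME assay on L6 cells (Rattus norvegicus) for cytotoxicity (a lower number here means a stronger inhibitor, a higher number a weaker inhibitor), so far:
compound 1 `CCc1ccc(C(=O)CC(=O)C2CCOCC2)cc1` gives 202000 nM
compound 2 `CSC(=CC(=O)c1ccc(Oc2ccc([N+](=O)[O-])cc2)cc1)SC` gives 156000 nM
compound 3 `CSC(=CC(=O)c1ccc([N+](=O)[O-])cc1)SC` gives 40500 nM

Of these three, compound 3 has the lowest number, and its gaps to compound 2 and to compound 1 both lie beyond the scatter. It is thus the strongest inhibitor of the set in this assay even though its value sits high on the scale.

Compound 4 `CSC(=CC(=O)c1ccc(Oc2ccccc2)cc1)SC` is still to be measured. It has phenoxy in place of nitro on an aromatic carbon of compound 3 phenoxy in place of nitro on an aromatic carbon and otherwise keeps the same structure.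

Within the data shown here, no measured pair differs in one place only, so no direct step guides this change. Among the measured compounds shown here, the only hint is that compound 2 at 156000 nM and compound 1 at 202000 nM both read higher than compound 3 does. A moderate move to a higher number, beyond the scatter, is therefore expected, which would mean a weaker inhibitor. The estimated change is a 2.2-fold higher number from compound 3 to compound 4 (0.35 log units; beyond the scatter) in this direction. For compound 4 the expected value is 90000 nM with an estimated range from 32000 nM to 210000 nM for the measurement.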

Compound 4, half-maximal inhibitory concentration: 34500 nM
Beside the measured number, compound 4's estimate is 2.6-fold (0.42 log units) above it, within the range that was stated.
By their numbers in this assay, from the lowest: compounds 4 and 3 (each within the scatter of the next); then compounds 2 and 1 (each within the scatter of the next).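

In this assay, phenoxy in place of nitro on the aromatic carbon gives a 1.2-fold lower number from compound 3 to compound 4 (0.07 log units; within the scatter), so the two compounds read alike and this position accepts either group without a change beyond the scatter. The nitro on the phenoxy ring does matter: hydrogen in place of that nitro gives a 4.5-fold lower number from compound 2 to compound 4 (0.66 log units; beyond the scatter), a modest step beyond the scatter, which shows that the same group can count in one place and not in another within this series. No measurement offered here accounts for either step.

On these data alone, whether an amine, a carboxylic acid or a methoxy group at this aromatic carbon would also read like nitro and phenoxy remains open. So does whether a group other than nitro on the phenoxy ring would give a step of similar size.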